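Aryl variation on the benzimidazole-propanoic acid series

The source may report more compounds than this note shows. Statements on the series, on what has been measured and on what is new or still open speak of the compounds shown alone.

Measured compounds:
compound 1, `O=C(O)CC(Cc1nc2cc(F)c(F)cc2[nH]1)c1ccc(Cl)cc1`, 50%
compound 2, `O=C(O)CC(Cc1nc2cc(Cl)ccc2[nH]1)c1ccc(Cl)c(F)c1`, 30%

Both compounds were run in an assay on isolated protein for inhibition of protein kinase C zeta type (Homo sapiens), read by 33P incorporation, tested at 200 uM; on this read-out higher numbers stand for a stronger effect at the one concentration tested and lower numbers for a weaker effect. Compound 1 gives 50%; compound 2 gives 30%. Compound 2 thus stands lowest of the two numbers, and its nearest neighbour, compound 1, lies higher by a margin beyond the usual scatter. Within the data shown here, the two compounds differ in more than one place, so no single step between them can be read off.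

Compound 3, `O=C(O)CC(Cc1nc2cc(Cl)ccc2[nH]1)c1cccc(Cl)c1`, has not yet been measured in this assay. It differs from compound 2 in one place: 3-chlorophenyl in place of 4-chloro-3-fluorophenyl on a saturated chain carbon bound to two saturated chain carbons. Nothing measured here isolates the effect of this change, so the expectation rests on the two numbers shown and on the modest size of the substitution. The step of a number 3 percentage points higher from compound 2 to compound 3 (within the scatter) is expected to be small, with no clear direction and most likely within the scatter. Compound 3 is therefore estimated to give 33% in this assay, with a plausible range from 10% to 58%.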

Compound 3, a percentage reported as inhibition, at one concentration (the size of the read-out at that concentration, not a potency): 0%
For compound 3 the middle estimate is 33 percentage points above the measured one; measured number outside the range, below it.
By their numbers in this assay, from the lowest: compound 3; then compound 2; then compound 1.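

In this assay, the aryl group on a saturated chain carbon bound to two saturated chain carbons turns out not to be a tolerant place: with the rest of the structure unchanged, 3-chlorophenyl in place of 4-chloro-3-fluorophenyl gives a number 30 percentage points lower from compound 2 to compound 3 (beyond the scatter). Among these compounds, this is the first step that can be read at a single place, and it takes the read-out down to nothing detectable, with compound 3 at 0% at the one concentration tested, so a modest change of halogen pattern on this aryl ring is enough to lose the effect entirely. No data at hand speak to the reason for this loss.

The group that enters differs from the one that leaves in two ways at once, having no fluorine and a chlorine at another ring position, and this single step does not tell which of the two matters. Unsubstituted phenyl or 3-fluorophenyl at the same place on the core of compound 2 would pull those two differences apart.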